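The source may report more compounds than this note shows. Statements on the series, on what has been measured and on what is new or still open speak of the compounds shown alone.

Compound 1 `O=C(Nc1ccccc1)c1cccc(Br)c1O` was examined in an ADME assay on HEK293 cells (Homo sapiens) for cytotoxicity, read by reporter gene assay and resazurin assay, with a stated time of 48 h (on this read-out higher numbers stand for lower toxicity in this test and lower numbers for higher toxicity in this test), where compound 1 gives 82000 nM. Among the three compounds measured, compound 1 has the highest number; compound 2 `O=C(Nc1ccc(Sc2nc3ccccc3s2)cc1)c1cccc(Br)c1O` gives 71000 nM in this assay, which lies within the scatter of compound 1, while compound 3 `O=C(Nc1cccc(Cl)c1)c1cccc(Br)c1O` gives 32000 nM, and the step of a 2.6-fold lower number from compound 1 to compound 3 (0.41 log units; beyond the scatter) goes beyond the scatter. Compound 4 `O=C(Nc1ccccc1)c1cccc(Br)c1` differs from compound 1 by hydrogen in place of hydroxy on an aromatic carbon. Among the measured compounds shown here, no measured step concerns the hydroxy group, so the one step known, a 2.6-fold lower number from compound 1 to compound 3 (0.41 log units; beyond the scatter), bears only loosely on this change. Compound 4 is therefore expected to sit close to compound 1, with a step of a 1.1-fold higher number from compound 1 to compound 4 (0.04 log units; within the scatter) not clearly beyond the scatter. The estimate for compound 4 in this assay is 90000 nM, with a range from 40000 nM to 200000 nM.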

Compound 4, half-maximal cytotoxic concentration: > 100000 nM
Compound 4 ended at the assay's limit; the forecaster's own chance of this, stated with the estimate: 20%; at least 1.1-fold (0.04 log units) between middle value and limit.
By their numbers in this assay, from the lowest: compound 3; then compounds 2 and 1 (each within the scatter of the next). At a limit, above all of these: compound 4.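

The result for compound 4 in this assay is a limit of the assay and not a number. Among the compounds shown here, it gives the only step here that concerns the hydroxy group, an at least 1.2-fold higher number from compound 1 to compound 4 (0.08 log units; that floor lies within the scatter), so hydrogen in place of hydroxy did not bring the number down, but the floor of this step does not establish a real rise. How far compound 4 lies from compound 1 cannot be read. On these data alone, it remains open whether a methoxy group or an amine at this place would give a number near that of compound 1, and whether chloro in place of hydrogen would lower the number without the hydroxy.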